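A few compounds are considered here, and "the series" means these few. Any claim that something is new, unique, unknown or untested is made for them only; others in the source may bear on it.

Series notes. Compound 1 `COc1ccc(-c2cc(C(C)=O)c3[nH]c(-c4ccccc4)cc3c2)cc1` and compound 2 `COc1ccc(-c2cc(C(C)=O)c3[nH]c(-c4ccc(F)cc4)cc3c2)cc1` share one core; compound 3 `CC(=O)c1cc(/C=C/c2ccccc2)cc2cc(-c3ccccc3)[nH]c12` and the not yet measured compound 4 `CC(=O)c1cc(/C=C/c2ccc(F)cc2)cc2cc(-c3ccccc3)[nH]c12` share another. How the two cores differ is counted in 2-phenylethenyl in place of 4-methoxyphenyl on an aromatic carbon. In a functional assay on MCF7 cells (Homo sapiens) for cytotoxicity, read by MTT assay, with a stated time of 2 days, tested at 10 uM (on this read-out higher numbers stand for a weaker effect at the one concentration tested and lower numbers for a stronger effect), compound 1 gives 49.5%, and compound 2 gives 52.9%, so that a number 3.4 percentage points higher from compound 1 to compound 2 (within the scatter). In this assay compound 3 gives 86.5%, and a number 37 percentage points higher from compound 1 to compound 3 (beyond the scatter); compound 3 stands furthest from the others of the three, its gaps to compound 1 and compound 2 both beyond the scatter.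

The change from compound 1 to compound 2 is fluoro in place of hydrogen on an aromatic carbon. The change from compound 3 to compound 4 is fluoro in place of hydrogen on an aromatic carbon; the place lines read the same word for word, so this is the same change on a different core. It was made once on a measured pair, with a step within the scatter.

On that basis the step in this assay is expected to be small, about a number 1.5 percentage points higher from compound 3 to compound 4 (within the scatter), because the earlier one was a number 3.4 percentage points higher from compound 1 to compound 2 (within the scatter). Compound 4 is accordingly estimated at 88%, between 74% and 99%, with the caveat that the step rests on a single measured pair on the other core.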

Compound 4, a percentage reported as activity, at one concentration (the size of the read-out at that concentration, not a potency): 46.5%
Compound 4: the middle estimate sits 41.5 percentage points above what was measured; measured number outside the range, below it.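

In this assay fluoro in place of hydrogen does not carry over unchanged from one core to the other: the same change on two cores in this assay, a number 3.4 percentage points higher (within the scatter) from compound 1 to compound 2 and a number 40 percentage points lower (beyond the scatter) from compound 3 to compound 4, 43.4 percentage points apart, beyond the scatter of two such steps. On the core of compound 3 the change is large, at a number 40 percentage points lower from compound 3 to compound 4 (beyond the scatter) and 2-(4-fluorophenyl)ethenyl in place of 4-methoxyphenyl then reads as a number 3 percentage points lower from compound 1 to compound 4 (within the scatter) on the single concentration tested. With one measured pair per core, this shows that the size of the step depends on the core in these four compounds, but it does not show which part of the core is responsible or how the change would behave on a third core.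

On these data alone, it remains open whether the step on the core of compound 3 is specific to fluoro or would also appear with chloro, methoxy or an amine on the same aromatic carbon. Also open, as far as these compounds go, is whether the step would hold at other concentrations, since a single-concentration read-out gives no potency.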